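This account rests on a few compounds, and the source may have more. Where it says the series, first, only, none or still open, it means among the compounds named here.

Measured compounds:
Compound 1 `O=C1COc2ccc(-c3cccc(NS(=O)(=O)c4ccc(F)cc4)c3)cc2N1c1ccccc1` gives > 40000 nM in a functional assay on A-375 cells (Homo sapiens) for antiproliferative activity, read by MTT assay, with a stated time of 72 h; on this read-out lower numbers stand for stronger inhibition and higher numbers for weaker inhibition; this value is a limit of the assay, not a number.
Compound 2 `O=C1COc2ccc(-c3cnc4ccccc4c3)cc2N1` gives > 40000 nM in this assay, again only a limit.
Compound 3 `O=C1COc2ccc(-c3cnc(Cl)c(NS(=O)(=O)c4ccc(F)cc4)c3)cc2N1` gives > 40000 nM in this assay, also a limit.

Compound 1 therefore stands at the limit itself, with nothing to rank it against (the limit of > 40000 nM in this assay, at which 3 of the 3 values shown sit). Nothing shown separates it from compound 2 or compound 3, since all three sit at the same limit. Compound 4 `Cc1ccc(N2C(=O)COc3ccc(-c4cccc(NS(=O)(=O)c5ccc(F)cc5)c4)cc32)cc1` differs from compound 1 in one place (methyl in place of hydrogen on an aromatic carbon). Among the compounds with values here, no measured pair shows what such a change does in this assay, so the expectation rests only on compound 1 sitting at the limit. The step from compound 1 to compound 4 is expected to be none beyond the scatter a number no higher from compound 1 to compound 4 (the limit leaves the size open); in other words, compound 4 is expected to remain at or near the limit. Compound 4 is estimated at 40000 nM, with a range from 15000 nM to 100000 nM, and most likely the assay will again report only a limit.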

Compound 4, half-maximal inhibitory concentration: 36200 nM
Compound 4: middle estimate off by 1.1-fold (0.04 log units), on the high side; low and high end bracket the measured number.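

In this assay compound 4 is the only compound shown that gives a number rather than a limit, so the change from phenyl to 4-methylphenyl, para to a large group, is the first to separate a compound from the rest. The step reads an at least 1.1-fold lower number from compound 1 to compound 4 (0.04 log units; that floor lies within the scatter); it is only a floor, so the real effect of the methyl group could be as small as the scatter or much larger. Even so, this single number lies close to where the other compounds stop: the limit of > 40000 nM in this assay, at which 3 of the 4 values shown sit.

The compounds shown leave open how an ethyl chain, a methoxy group or an amine in the same place would compare with the methyl group. They also leave open whether a methyl group elsewhere on that ring would give a measurable number.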